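A few compounds are considered here, and "the series" means these few. Any claim that something is new, unique, unknown or untested is made for them only; others in the source may bear on it.

Working notes on the series. In a functional assay on HepG2 cells (Homo sapiens) for inhibition, read by MTT assay, with a stated time of 48 h (on this read-out higher numbers stand for weaker inhibition and lower numbers for stronger inhibition), compound 1, `Fc1cccc(F)c1CSc1nnc(-c2ccncc2)n1-c1ccccc1`, gives > 50000 nM, which is a limit of the assay and not a number. Compound 2, `O=C(CSc1nnc(-c2ccncc2)n1-c1ccccc1)N/N=C/c1ccc(O)cc1`, gives in this assay > 50000 nM, again a limit rather than a measured number. Where compound 2 stands on the numbers shown is therefore only a bound: both values shown sit at the limit of > 50000 nM in this assay, at which 2 of the 2 values shown sit, so no step between measured compounds can be stated, and nothing in the numbers separates compound 2 from compound 1 in this assay. Compound 3, `O=C(CSc1nnc(-c2ccncc2)n1-c1ccccc1)N/N=C/c1cc(Br)cc(Br)c1O`, is not yet measured. It differs from compound 2 by 3,5-dibromo-2-hydroxyphenyl in place of 4-hydroxyphenyl on a carbon with a double bond to nitrogen. With both measured values at the limit, the numbers shown give no basis for a step of any size in this assay in either direction. For compound 3 the step expected is a step that the limit leaves unreadable from compound 2 to compound 3, none beyond the scatter, and the most likely outcome is again a limit. The estimate for compound 3 in this assay is 60000 nM, with a range from 20000 nM to 200000 nM.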

Compound 3, half-maximal inhibitory concentration: 7590 nM
The estimate for compound 3 lay 7.9-fold (0.90 log units) above the measured number; the measured number lies below the stated range.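

In this assay, among the compounds shown here, 3,5-dibromo-2-hydroxyphenyl in place of 4-hydroxyphenyl on a carbon with a double bond to nitrogen gives an at least 6.5-fold lower number from compound 2 to compound 3 (0.81 log units; beyond the scatter), the only step that can be read. The position is therefore not silent: a change in this one group brings the read-out off the limit, which compounds 1 and 2 could not show, since neither gave a measured number. The step remains a bound and not a true size, because compound 2 gives only a limit and its real value stays unknown: the limit of > 50000 nM in this assay, at which 2 of the 3 values shown sit.

The change alters the bromine content and the place of the hydroxyl in one move, so the compounds shown do not separate the two, and neither 2-hydroxyphenyl without bromine nor 3,5-dibromophenyl without the hydroxyl is among them. Going by these compounds, it also stays open whether another halogen, as in 3,5-dichloro-2-hydroxyphenyl, or an amine or a carboxylic acid on the same ring would give a measured number in this assay.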